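The compounds below may be only part of what the source reports. "The series", "measured", "known", "first", "only" and "open" are said of these compounds alone.

Measured in an ADME assay on Vero cells (Chlorocebus sabaeus) for cytotoxicity, read by MTT assay, with a stated time of 72 h; a higher number here means that more compound is tolerated, a lower number that less compound is tolerated:
- compound 1 `COc1ccc(-c2cc(-c3ccc(C4NC(=O)c5ccccc5N4)cc3)nc(N)n2)cc1`: 124000 nM
- compound 2 `CC(C)c1ccc(C(Nc2ccc(C3(C)NC(=O)c4ccccc4N3)cc2)c2nnnn2C2CCCCC2)cc1`: > 400000 nM (a limit, not a number)
- compound 3 `CCCCCNc1nc(NCCCCC)nc(Nc2ccc(C3(C)NC(=O)c4ccccc4N3)cc2)n1`: > 400000 nM (a limit, not a number)

Going by the values given here, compound 1 holds the only true number in this set. The other two entries are limits, as summarised by the limit of > 400000 nM in this assay, at which 2 of the 3 values shown sit. The two values therefore show that compound 2 and compound 3 reached the limit while compound 1 gave a number, but they give no size for any gap.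

Compound 4 `CN1CCN(c2ccc(-c3cc(-c4ccc(C5NC(=O)c6ccccc6N5)cc4)nc(N)n3)cc2)CC1` keeps the core of compound 1 and carries 4-methylpiperazin-1-yl in place of methoxy on an aromatic carbon, para to a large group (4-methylpiperazin-1-yl in place of methoxy on an aromatic carbon). Among the compounds with values here, no measured pair isolates this change, so the only anchor is compound 1 at 124000 nM. In this assay, the expected outcome is no change beyond the scatter, with a slight lean towards less compound being tolerated: a 1.2-fold lower number from compound 1 to compound 4 (0.09 log units; within the scatter) is the estimated step. For compound 4 the estimated value is 100000 nM, with an expected range of 30000 nM to 300000 nM.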

Compound 4, half-maximal cytotoxic concentration: 8320 nM
The estimate for compound 4 lay 12-fold (1.08 log units) above the measured number; measured number below the stated range.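

In this assay, going by these compounds alone, the aromatic carbon para to a large group proves sensitive to the group it carries: 4-methylpiperazin-1-yl in place of methoxy gives a 15-fold lower number from compound 1 to compound 4 (1.17 log units; beyond the scatter) and so the first readable step. Within the data shown here, the earlier compounds held only one true number, so they could not show that a change at this position moves the read-out at all. The entries for compound 2 and compound 3 remain limits, not numbers, and offer no second step to set against this one: the limit of > 400000 nM in this assay, at which 2 of the 4 values shown sit.

On these data alone, whether the step belongs to the ring, its second nitrogen or its methyl group stays open. A morpholin-4-yl, a piperazin-1-yl without the methyl or an open-chain dimethylamino group on the same carbon would separate these parts.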